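Trifluoromethyl to bromo in a small antiproliferative series

This account rests on a few compounds, and the source may have more. Where it says the series, first, only, none or still open, it means among the compounds named here.

In a functional assay on A549 cells (Homo sapiens) for antiproliferative activity, read by MTT assay, with a stated time of 48 h (a higher number here means a weaker inhibitor, a lower number a stronger inhibitor), compound 1 (`Cc1ccc(-c2cc(NC(=O)/C=C/c3ccc(C(F)(F)F)cc3)n[nH]2)cc1`) gives 1020 nM. Compound 2 (`COc1ccc(/C=C\C(=O)Nc2cc(-c3ccccc3)[nH]n2)cc1`) gives 1060 nM, and compound 3 (`O=C(/C=C/c1ccccc1)Nc1cc(-c2ccc(Br)cc2)[nH]n1`) gives 1440 nM. Both values lie within the usual scatter of the value for compound 1, so the three numbers form a single group and set no order among these compounds.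

Compound 4 (`Cc1ccc(-c2cc(NC(=O)/C=C/c3ccc(Br)cc3)n[nH]2)cc1`) has not yet been measured in this assay. It differs from compound 1 in one place, with bromo in place of trifluoromethyl on an aromatic carbon of a six-membered aromatic ring of carbon only, para to a large group: bromo in place of trifluoromethyl on an aromatic carbon. For the measured compounds named here, no two measured compounds differ in a single place, so the data give no direct measure of what such a change does. Going by the values given here, the only indirect guide is compound 3, which also carries a bromo group, though elsewhere in its structure, and gives 1440 nM. That value stays within the scatter of the other two, so no step beyond the scatter is expected, in either direction. The expected change is a 1.1-fold higher number from compound 1 to compound 4 (0.03 log units; within the scatter). For compound 4 the estimated value is 1100 nM, with an expected range from 500 nM to 2400 nM.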

Compound 4, half-maximal inhibitory concentration: 1590 nM
Compound 4: middle estimate off by 1.4-fold (0.16 log units), on the low side; low and high end bracket the measured number.
By their numbers in this assay, from the lowest: compounds 1, 2, 3 and 4 (each within the scatter of the next).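

For the compounds shown here, this is the first pair that differs in one place only, so it gives the first direct reading of bromo in place of trifluoromethyl on an aromatic carbon, para to a large group, in this assay. Replacing trifluoromethyl, with its 4 heavy atoms, by bromo, with its 1 heavy atom, gives a 1.6-fold higher number from compound 1 to compound 4 (0.19 log units; within the scatter), and this step lies within the scatter, so the two groups cannot be told apart at this position on the core of compound 1. No measurement at hand bears on what lies behind this reading.

The compounds shown leave open whether this position tolerates groups of another kind, such as a nitrile, an amine or a carboxylic acid, since only trifluoromethyl and bromo are compared here on the core of compound 1. They also leave open whether the same change would read the same way at any other place on that core, as this single pair speaks only for the position it covers.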